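This account rests on a few compounds, and the source may have more. Where it says the series, first, only, none or still open, it means among the compounds named here.

Working notes on the series. In a functional assay on MCF7 cells (Homo sapiens) for cytotoxicity, read by MTT assay, with a stated time of 48 h (on this read-out higher numbers stand for weaker inhibition and lower numbers for stronger inhibition), compound 1 (`C=C1OC(=O)C=C1Cc1ccc(NC(=O)/C=C/c2ccccc2)cc1`) gives 9490 nM, compound 2 (`C=C1OC(=O)C=C1Cc1ccc(NC(=O)/C=C/c2ccccc2F)cc1`) gives 13800 nM and compound 3 (`O=C(/C=C/c1ccc(F)cc1)Nc1ccc(CC2=CC(=O)OC2)cc1`) gives 47900 nM. Compound 3 has the highest number of the three, and its gaps to the other two lie beyond the usual scatter. Compound 4 (`C=C1OC(=O)C=C1Cc1ccc(NC(=O)/C=C/c2ccc(F)cc2)cc1`) differs from compound 3 in one place: a group of 7 heavy atoms (5 carbon, 2 oxygen; one five-membered non-aromatic ring with 1 hetero atom) in place of a group of 6 heavy atoms (4 carbon, 2 oxygen; one five-membered non-aromatic ring with 1 hetero atom), on a saturated chain carbon bound to an aromatic carbon. Within the data shown here, no measured step shows this change on its own. Among the measured compounds shown here, the only measured step, a 1.5-fold higher number from compound 1 to compound 2 (0.16 log units; within the scatter), is fluoro in place of hydrogen on an aromatic carbon, and it lies within the scatter. Compound 4 shares the group of 7 heavy atoms with compound 1 and compound 2 and carries a fluoro, as compound 2 does, so its number is expected near theirs rather than near that of compound 3. In this assay a lower number beyond the scatter is therefore expected, an estimated 4.0-fold lower number from compound 3 to compound 4 (0.60 log units; beyond the scatter). For compound 4 the estimate is 12000 nM, with an expected range of 6000 nM to 24000 nM.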

Compound 4, half-maximal inhibitory concentration: 4430 nM
Compound 4: middle estimate off by 2.7-fold (0.43 log units), on the high side, outside the stated range (below it).
By their numbers in this assay, from the lowest: compound 4; then compounds 1 and 2 (each within the scatter of the next); then compound 3.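

In this assay, the group with 3 double bonds outside aromatic rings, on a saturated chain carbon bound to an aromatic carbon, makes a large difference when it replaces the group with 2 such bonds (an 11-fold lower number from compound 3 to compound 4 (1.03 log units; beyond the scatter)). The fluoro also matters in a way the earlier step within the scatter did not reveal: fluoro in place of hydrogen now gives a step beyond the scatter (a 2.1-fold lower number from compound 1 to compound 4 (0.33 log units; beyond the scatter)), and 4-fluorophenyl in place of 2-fluorophenyl gives a modest step of its own (a 3.1-fold lower number from compound 2 to compound 4 (0.49 log units; beyond the scatter)). Nothing available here accounts for either finding.

Going by these compounds, the effect of exchanging the ring group is read only with 4-fluorophenyl present, so its size alongside phenyl or 2-fluorophenyl remains open. Also open, on these data alone, is how a chloro or methoxy in place of the fluoro, or a longer chain in place of the saturated chain carbon, would read.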